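Flipping Two Ring Stereocentres in a Hydroxamate Series

This account rests on a few compounds, and the source may have more. Where it says the series, first, only, none or still open, it means among the compounds named here.

Compound 1 `O=C(/C=C/c1cn([C@@H]2C[C@@H](C(=O)O)N(CCCc3ccccc3)C2)nn1)NO`: < 10%
Compound 2 `O=C(/C=C/c1cn([C@@H]2C[C@@H](C(=O)O)N(Cc3ccccc3)C2)nn1)NO`: 12%
Compound 3 `O=C(/C=C/c1cn([C@@H]2C[C@@H](CO)N(CCCc3ccccc3)C2)nn1)NO`: 13%

The three compounds were tested in an assay on Sf9 cells for inhibition of histone deacetylase 11 (Homo sapiens), read by fluorescence, tested at 0.5 uM; on this read-out higher numbers stand for more inhibition at the one concentration tested (going by the name of the read-out) and lower numbers for less inhibition. In this assay compound 1 gives < 10%, which is a limit of the assay and not a measured number. Compound 1 therefore stands at the limit of < 10% in this assay, at which 1 of the 3 values shown sits.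

Two measured steps start from compound 1. Putting phenyl in place of phenethyl on a saturated chain carbon bound to an amine nitrogen in a ring gives a number at least 2 percentage points higher from compound 1 to compound 2 (that floor lies within the scatter). Putting hydroxymethyl in place of carboxy on a saturated ring carbon gives a number at least 3 percentage points higher from compound 1 to compound 3 (that floor lies within the scatter). Both steps lie within the scatter of the assay, so neither shows a real change.

Compound 4 `O=C(/C=C/c1cn([C@H]2C[C@H](C(=O)O)N(CCCc3ccccc3)C2)nn1)NO` keeps every atom and bond of compound 1 and differs as follows: the two compounds have the same atoms and bonds and differ only in configuration as drawn: 2 of 3 stereo elements differ; a stereocentre at a saturated ring carbon is drawn R in compound 1 and S in compound 4; a stereocentre at a saturated ring carbon is drawn S in compound 1 and R in compound 4. Among the compounds with values here, neither measured step concerns configuration, so no measured step bears on this change, and the data offer no guide to its size or direction. With compound 1 itself at a limit, the expectation for compound 4 is a step that the limit leaves unreadable from compound 1 to compound 4, that is, nothing beyond the scatter. Compound 4 is therefore estimated at 8%, with a range from 0% to 22%, and it may again come out only as a limit.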

Compound 4, a percentage reported as inhibition, at one concentration (the size of the read-out at that concentration, not a potency): 20%
Compound 4: the middle estimate sits 12 percentage points below what was measured; the range from low to high includes it.
By their numbers in this assay, from the lowest: compounds 2, 3 and 4 (each within the scatter of the next). At a limit, below all of these: compound 1.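

Inverting the two stereocentres at saturated ring carbons, with no atom or bond changed, gives in this assay a number at least 10 percentage points higher from compound 1 to compound 4 (that floor lies within the scatter). Within the data shown here, this is the only step here that concerns configuration, and like the two earlier steps from compound 1 it stays within the scatter, so it does not establish a real change at these ring carbons. Compound 1 is reported only as a limit of the assay, not as a number, which means that the true size of this step cannot be read: the limit of < 10% in this assay, at which 1 of the 4 values shown sits.

The compounds shown leave open how each of the two ring stereocentres behaves alone, since here they change only together, and whether the configuration of compound 4 would give a similar number with hydroxymethyl in place of carboxy or with a shorter chain on the amine nitrogen in the ring. They also leave open what an ester or an amide in place of the carboxy group, or a longer chain on that nitrogen, would give in this assay with the configuration of compound 4.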